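This account rests on a few compounds, and the source may have more. Where it says the series, first, only, none or still open, it means among the compounds named here.

Series notes. Compound 1 `CN(C(=O)NC(=O)c1ccccc1F)c1nc(C(F)(F)F)c(C(=O)N/N=C/c2cc(C(F)(F)F)cc(C(F)(F)F)c2)s1` carries a methylated urea linked to a fluorinated benzoyl group on one side of the shared core and an acyl hydrazone bearing a bis(trifluoromethyl)phenyl group on the other. In a functional assay on BCG823 cells (Homo sapiens) for inhibition, read by MTT assay, with a stated time of 72 h (a lower number here means a stronger inhibitor, a higher number a weaker inhibitor), compound 1 gives 4.23 ug/mL. Its companion, compound 2 `CN(C(=O)NC(=O)c1ccccc1F)c1nc(C(F)(F)F)c(C(=O)N/N=C/c2ccccc2C(F)(F)F)s1`, differs in the aryl part of the hydrazone; in this assay compound 2 gives 4.67 ug/mL. Compound 1 stands at the lower of the two numbers, but the gap to compound 2 lies within the scatter, so the two are not distinguishable on these data.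

Compound 3 `CN(C(=O)NC(=O)c1c(F)cccc1F)c1nc(C(F)(F)F)c(C(=O)N/N=C/c2cc(C(F)(F)F)cc(C(F)(F)F)c2)s1` follows from compound 1 by one change, (fluoro in place of hydrogen on an aromatic carbon), that is, 2-fluorophenyl to 2,6-difluorophenyl on the benzoyl side. Within the data shown here, no measured pair in the set isolates this change, so nothing in the data fixes its direction or size. The two measured compounds sit close together, and a single added fluoro on the benzoyl ring is expected to move the number by no more than the scatter; the step from compound 1 to compound 3 in this assay is estimated at a 1.1-fold lower number from compound 1 to compound 3 (0.02 log units; within the scatter). For compound 3 the expected value in this assay is 4 ug/mL, with a range from 2 ug/mL to 8 ug/mL.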

Compound 3, half-maximal inhibitory concentration: 5.28 ug/mL
Estimate against measurement, compound 3: 1.3-fold (0.12 log units) below, within the range that was stated.
By their numbers in this assay, from the lowest: compounds 1, 2 and 3 (each within the scatter of the next).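

Among these compounds, compound 3 gives the first reading on the benzoyl side of the series, where compounds 1 and 2 share the same 2-fluorophenyl group. In this assay the change from 2-fluorophenyl to 2,6-difluorophenyl, fluoro in place of hydrogen on an aromatic carbon ortho to a large group, gives a 1.2-fold higher number from compound 1 to compound 3 (0.10 log units; within the scatter) and so stays within the scatter, which means that on this one pair a second fluoro at this place is tolerated with no measurable penalty or gain. Nothing in the data bears on why the step has this size.

The compounds shown leave open whether a group other than fluoro at this ring carbon, such as a methoxy group or an amine, or a plain phenyl in place of the 2-fluorophenyl, would move the number beyond the scatter. They also leave open whether the same fluoro step would hold on the 2-(trifluoromethyl)phenyl hydrazone of compound 2, since the step has been read on only one hydrazone.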